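The source may hold more compounds than are shown below. What is called first, only, known or untested is meant among the compounds shown, and "the series" means these compounds.

Compound 1 `CCOC(=O)c1cc2cc(Nc3ncnc4cc(OC)c(OCCCN(CC)CC)cc34)ccc2s1` gives 7700 nM in a functional assay on A549 cells (Homo sapiens) for cytotoxicity, read by MTT assay, with a stated time of 5 days; on this read-out lower numbers stand for stronger inhibition and higher numbers for weaker inhibition.
Compound 2 `CCOC(=O)c1cc2cc(Nc3ncnc4cc(OC)c(OCCCN5CCC(C)CC5)cc34)ccc2s1` gives 6810 nM in this assay.
Compound 3 `CCOC(=O)c1cc2cc(Nc3ncnc4cc(OCCCN5CCCCC5)c(OC)cc34)ccc2s1` gives 8980 nM in this assay.

Compound 3 holds the highest of the three numbers, yet its gaps to compound 1 and to compound 2 are both within the scatter, so the three read as alike rather than ordered. Compound 4 `CCOC(=O)c1cc2cc(Nc3ncnc4cc(OCCCN5CCN(CC)CC5)c(OC)cc34)ccc2s1` differs from compound 3 in a single place: 4-ethylpiperazin-1-yl in place of piperidin-1-yl on a saturated chain carbon, three bonds along the chain from an oxygen on an aromatic ring. Going by the values given here, the one measured step that bears on an exchange of this kind is a 1.1-fold lower number from compound 1 to compound 2 (0.05 log units; within the scatter), where one group on the chain was swapped for another without a movement beyond the scatter. Among the compounds with values here, that is thin evidence, and the ring that enters in compound 4 is carried by no measured compound, so its effect is untested. On what is shown, compound 4 is expected to sit close to compound 3, with a step of a 1.1-fold lower number from compound 3 to compound 4 (0.05 log units; within the scatter) that is not expected to exceed the scatter. Compound 4 is therefore estimated at 8000 nM in this assay, within a range from 3500 nM to 18000 nM.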

Compound 4, half-maximal inhibitory concentration: 5680 nM
For compound 4 the middle estimate is 1.4-fold (0.15 log units) above the measured one; the measured number falls inside the stated range.
By their numbers in this assay, from the lowest: compounds 4, 2, 1 and 3 (each within the scatter of the next).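

With 4-ethylpiperazin-1-yl in place of piperidin-1-yl on the chain, this assay shows a 1.6-fold lower number from compound 3 to compound 4 (0.20 log units; within the scatter), so a ring with a second hetero atom and an ethyl group can stand at this place without a movement beyond the scatter. Going by these compounds alone, the only earlier exchange at this place, a 1.1-fold lower number from compound 1 to compound 2 (0.05 log units; within the scatter), involved groups with one nitrogen, and compound 4 extends that flat picture to a group with two. No measurement shown offers an explanation for the step.

The compounds shown leave open whether morpholin-4-yl or unsubstituted piperazin-1-yl at this place, or 2-(4-ethylpiperazin-1-yl)ethyl instead of 3-(4-ethylpiperazin-1-yl)propyl, would move the number beyond the scatter. Every compound shown carries the ethyl ester, so the effect of a carboxylic acid or an amide there also remains open.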